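Hydroxy for methyl on the aryl ketone of compound 2

The compounds below may be only part of what the source reports. "The series", "measured", "known", "first", "only" and "open" are said of these compounds alone.

Compound 2 `Cc1cccc(C(=O)/C=C/c2ccc3c(c2)B(O)OC3)c1` gives 2900 nM in a functional assay on SK-OV-3 cells (Homo sapiens) for cytotoxicity, read by MTT assay, with a stated time of 48 h (on this read-out higher numbers stand for weaker inhibition and lower numbers for stronger inhibition), numerically the lower of the two values recorded. Compound 1 `O=C(/C=C/c1ccc2c(c1)B(O)OC2)c1ccccc1F` gives 3700 nM in this assay. The step of a 1.3-fold lower number from compound 1 to compound 2 (0.11 log units; within the scatter) lies within the scatter. Compound 3 `O=C(/C=C/c1ccc2c(c1)B(O)OC2)c1cccc(O)c1` differs from compound 2 by hydroxy in place of methyl on an aromatic carbon. Among the measured compounds shown here, no measured step exchanges a methyl for a hydroxy, and the single step available, a 1.3-fold lower number from compound 1 to compound 2 (0.11 log units; within the scatter), was small. Compound 3 is therefore expected to give about 3000 nM, between 1200 nM and 7500 nM, a change of a 1.0-fold higher number from compound 2 to compound 3 (0.01 log units; within the scatter) that is not expected to exceed the scatter.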

Compound 3, half-maximal inhibitory concentration: 3800 nM
Beside the measured number, compound 3's estimate is 1.3-fold (0.10 log units) below it; low and high end bracket the measured number.
By their numbers in this assay, from the lowest: compounds 2, 1 and 3 (each within the scatter of the next).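

In this assay, hydroxy in place of methyl on this aromatic carbon gives a 1.3-fold higher number from compound 2 to compound 3 (0.12 log units; within the scatter), so adding a hydrogen-bond donor and acceptor here moves the number no further than the scatter. The exchange of 2-fluorophenyl for 3-hydroxyphenyl on the carbonyl carbon gives a 1.0-fold higher number from compound 1 to compound 3 (0.01 log units; within the scatter), which leaves all three aryl groups within the scatter of one another. Nothing available explains this result.

From the compounds shown here alone, whether an amine, a carboxylic acid or a longer chain on this aromatic carbon would shift the number beyond the scatter remains open.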